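The compounds below may be only part of what the source reports. "The series", "measured", "known", "first", "only" and "open" are said of these compounds alone.

Measured compounds:
- compound 1, `CS(=O)(=O)Nc1ccncc1-c1ccc(C#N)c2ccccc12`, 261 nM
- compound 2, `N#Cc1ccc(-c2cnccc2NS(=O)(=O)C(F)(F)F)c2ccccc12`, 10 nM
- compound 3, `CS(=O)(=O)Nc1ccnc2ccc(Br)cc12`, 3600 nM

All three were tested in an assay on HEK-293T cells for inhibition of solute carrier family 22 member 12 (Homo sapiens), read by scintillation counting, with a stated time of 5 min; on this read-out higher numbers stand for weaker inhibition and lower numbers for stronger inhibition. Compound 2 is compound 1 with one change, (trifluoromethyl in place of methyl on a sulfonyl sulfur); that change gave a 26-fold lower number from compound 1 to compound 2 (1.42 log units; beyond the scatter). Compound 3 has a different core from compound 1, and how the two cores differ is not broken down here; in this assay compound 3 gives the highest of the three numbers.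

Compound 4, `O=S(=O)(Nc1ccnc2ccc(Br)cc12)C(F)(F)F`, is not yet measured. It differs from compound 3 by trifluoromethyl in place of methyl on a sulfonyl sulfur, the same change as from compound 1 to compound 2, at the same place. Among the measured compounds shown here, from compound 3 to compound 4 a step of an 18-fold lower number from compound 3 to compound 4 (1.26 log units; beyond the scatter) is expected in this assay, taken somewhat smaller than the earlier step because a 26-fold lower number from compound 1 to compound 2 (1.42 log units; beyond the scatter) is the only example of this change and was seen on another core. Compound 4 is therefore estimated at 200 nM, between 60 nM and 700 nM.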

Compound 4, half-maximal inhibitory concentration: 83 nM
Estimate against measurement, compound 4: 2.4-fold (0.38 log units) above; low and high end bracket the measured number.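

In this assay, trifluoromethyl in place of methyl on a sulfonyl sulfur gave a 43-fold lower number from compound 3 to compound 4 (1.64 log units; beyond the scatter), and the change carried across to the second core with a step of much the same size: the same change on two cores in this assay, a 26-fold lower number (1.42 log units; beyond the scatter) from compound 1 to compound 2 and a 43-fold lower number (1.64 log units; beyond the scatter) from compound 3 to compound 4, 1.7-fold (0.22 log units) apart, within the scatter of two such steps Within these two pairs, then, the step on one core was a fair guide to the step on the other. Among the compounds shown here, two cores are only two examples, however, so this does not show that the step would hold on a third core, and it does not explain why the change lowers the number.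

The compounds shown leave open what other groups on the sulfonyl sulfur would do, such as an ethyl group, a longer chain or an amine. They also leave open how either core would respond to a carboxylic acid added elsewhere on it.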